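The source may hold more compounds than are shown below. What is called first, only, known or untested is meant among the compounds shown, and "the series" means these compounds.

Working notes on the series. Compound 1 `O=C(O)CCn1c(=O)oc2cc(OCc3ccccc3)c(Cl)cc21` gives 25.1 nM in an assay for inhibition of kynurenine 3-monooxygenase (Homo sapiens), read by mass spectrometry, with a stated time of 1 h; a higher number here means a weaker inhibitor, a lower number a stronger inhibitor. Compound 2 `CC(C)Cc1cc2oc(=O)n(CCC(=O)O)c2cc1Cl` gives 12.6 nM in this assay; the step is a 2.0-fold lower number from compound 1 to compound 2 (0.30 log units; within the scatter), so the two values sit within the scatter of each other. Compound 3 `O=C(O)CCn1c(=O)oc2cc(OCc3ccccn3)c(Cl)cc21` differs from compound 2 by (pyridin-2-yl)methoxy in place of isobutyl on an aromatic carbon. Within the data shown here, the one measured step bearing on this change, benzyloxy to isobutyl, stayed within the scatter, and compound 3 carries (pyridin-2-yl)methoxy where compound 1 carries benzyloxy, so the expected step is a 1.6-fold higher number from compound 2 to compound 3 (0.20 log units; within the scatter), nothing beyond the scatter. Compound 3 is estimated at 20 nM, range 8 nM to 60 nM.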

Compound 3, half-maximal inhibitory concentration in the kynurenine 3-monooxygenase assay: 3.16 nM
Compound 3: middle estimate off by 6.3-fold (0.80 log units), on the high side; measured number outside the range, below it.
By their numbers in the kynurenine 3-monooxygenase assay, from the lowest: compound 3; then compounds 2 and 1 (each within the scatter of the next).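

Among these compounds, in the kynurenine 3-monooxygenase assay, the pyridin-2-yl group gives the first steps beyond the scatter: a 7.9-fold lower number from compound 1 to compound 3 (0.90 log units; beyond the scatter), and a 4.0-fold lower number from compound 2 to compound 3 (0.60 log units; beyond the scatter). This shows that the position responds to the ring on the methoxy chain, which the step from benzyloxy to isobutyl did not show. In a physicochemical assay for permeability, using PAMPA (a higher number here means that the compound crosses the layer faster, a lower number that the compound crosses the layer more slowly), compound 2 gives < 10 nm/s, which is a limit of the assay, and so that comparison cannot be read as a size: the limit of < 10 nm/s in the physicochemical assay, at which 1 of the 2 values shown sits.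

In the physicochemical assay compound 3 gives 11 nm/s. On these data alone, whether the lower number in the kynurenine 3-monooxygenase assay holds for (pyridin-3-yl)methoxy or (pyridin-4-yl)methoxy, or for an amine on that ring, remains open.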